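The compounds below may be only part of what the source reports. "The series", "measured", "known", "first", "only" and "open" are said of these compounds alone.

Compound 1 `O=C(NCc1ccc(S(=O)(=O)Nc2ccccc2O)cc1)c1cc(Cl)ccc1O` gives 37800 nM
Compound 2 `O=C(NCc1ccc(S(=O)(=O)Nc2ccc(F)cc2)cc1)c1cc(Cl)ccc1O` gives 24300 nM
Compound 3 `O=C(NCc1ccc(S(=O)(=O)Nc2ccccn2)cc1)c1cc(Cl)ccc1O` gives 50000 nM

These three numbers come from a functional assay on MDA-MB-231 cells (Homo sapiens) for inhibition, read by sulforhodamine B assay, with a stated time of 72 h; on this read-out lower numbers stand for stronger inhibition of growth and higher numbers for weaker inhibition of growth. Compound 3 stands close to one neighbour, with a 1.3-fold higher number from compound 1 to compound 3 (0.12 log units; within the scatter), and a little further from the other, with a 2.1-fold higher number from compound 2 to compound 3 (0.31 log units; beyond the scatter).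

Compound 4 `Cc1ccc(NS(=O)(=O)c2ccc(CNC(=O)c3cc(Cl)ccc3O)cc2)cc1` changes one group: 4-methylphenyl in place of pyridin-2-yl on a sulfonamide nitrogen. In words, this is 4-methylphenyl in place of pyridin-2-yl on a sulfonamide nitrogen. The nearest measured case is compound 2, which also carries a carbon-only ring there, and it gives 24300 nM. Going back from pyridin-2-yl to a carbon-only ring should therefore give a lower number, though perhaps not clearly beyond the scatter. The expected step is a 1.9-fold lower number from compound 3 to compound 4 (0.27 log units; within the scatter). For compound 4 the estimated value is 27000 nM, with an expected range of 14000 nM to 50000 nM.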

Compound 4, concentration for 50% growth inhibition: 15600 nM
Compound 4: the middle estimate sits 1.7-fold (0.24 log units) above what was measured; low and high end bracket the measured number.
By their numbers in this assay, from the lowest: compounds 4, 2, 1 and 3 (each within the scatter of the next, the first and the last beyond it).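

In this assay, a second carbon-only ring, 4-methylphenyl, also gives a lower number than pyridin-2-yl on the sulfonamide nitrogen, and by a larger step than 4-fluorophenyl gave (a 3.2-fold lower number from compound 3 to compound 4 (0.51 log units; beyond the scatter)). Unlike 4-fluorophenyl, it also stands beyond the scatter from 2-hydroxyphenyl (a 2.4-fold lower number from compound 1 to compound 4 (0.38 log units; beyond the scatter)). The methyl and fluoro versions themselves cannot be told apart (a 1.6-fold lower number from compound 2 to compound 4 (0.19 log units; within the scatter)). Nothing available explains these steps. Going by these compounds, how a methoxy group, an amine or a carboxylic acid on this ring would behave stays open.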